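Methyl for nitro in a series at the assay limit

The source may hold more compounds than are shown below. What is called first, only, known or untested is meant among the compounds shown, and "the series" means these compounds.

Compound 1 `Nc1ccccc1NC(=O)c1ccc(COc2ccc([N+](=O)[O-])cc2)cc1` gives > 32000 nM as a limit
Compound 2 `Nc1ccccc1NC(=O)/C=C/c1ccc(COc2ccccc2)cc1` gives > 32000 nM as a limit

Compound 1 gives no number in a functional assay on A549 cells (Homo sapiens) for antiproliferative activity, read by CCK-8 assay, with a stated time of 72 h; on this read-out lower numbers stand for stronger inhibition and higher numbers for weaker inhibition (the limit of > 32000 nM in this assay, at which 2 of the 2 values shown sit), so its place in the series is known only as a limit. Compound 3 `Cc1ccc(OCc2ccc(C(=O)Nc3ccccc3N)cc2)cc1` differs from it by methyl in place of nitro on an aromatic carbon. No measured step sizes this change, so no step beyond the scatter is expected in this assay and another limit is likely. The estimated step is a number no higher from compound 1 to compound 3 (the limit leaves the size open). That expectation rests only on compound 1, whose > 32000 nM is a limit shared with compound 2. Compound 3 is estimated at 32000 nM (expected range 12000 nM to 64000 nM).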

Compound 3, half-maximal inhibitory concentration: 5430 nM
Compound 3: middle estimate off by 5.9-fold (0.77 log units), on the high side; measured number below the stated range.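

Methyl in place of nitro, para to a large group, gives an at least 5.8-fold lower number from compound 1 to compound 3 (0.77 log units; beyond the scatter) in this assay, so activity in this series responds to the group at this position. Compound 3 is the only compound shown with a number rather than a limit, which gives later changes here a reference. The step has no upper size, as compound 1 carries only a limit: the limit of > 32000 nM in this assay, at which 2 of the 3 values shown sit.

From the compounds shown here alone, whether methyl itself favours activity or nitro disfavours it remains open. How an amine, a methoxy group or chlorine would compare at this position is also unknown.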